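A Second Chloro Placement on the Shared Core

The compounds below may be only part of what the source reports. "The series", "measured", "known", "first", "only" and "open" are said of these compounds alone.

Compound 1 `O=S(=O)(/C=C/c1ccccn1)c1ccccc1F`: 1050 nM
Compound 2 `O=S(=O)(/C=C/c1ncccc1F)c1ccccc1F`: 176 nM
Compound 3 `O=S(=O)(/C=C/c1ncccc1Cl)c1ccccc1F`: 30 nM

All three were tested in an assay on U2OS cells for activation of nuclear factor erythroid 2-related factor 2 (Homo sapiens), read by beta-arrestin recruitment, with a stated time of 6 h; a higher number here means that more compound is needed for the effect, a lower number that less compound is needed. Among them, compound 1 gives the highest number. Replacing its hydrogen with fluoro gives a 6.0-fold lower number from compound 1 to compound 2 (0.78 log units; beyond the scatter), and replacing it with chloro gives a 35-fold lower number from compound 1 to compound 3 (1.54 log units; beyond the scatter); moving from fluoro to chloro gives a 5.9-fold lower number from compound 2 to compound 3 (0.77 log units; beyond the scatter). Compound 4 `O=S(=O)(/C=C/c1cccc(Cl)n1)c1ccccc1F` differs from compound 1 by chloro in place of hydrogen on an aromatic carbon. The step from compound 1 to compound 3 is the only measured one that also introduces chloro, so it bears most on this case, but compound 4 is not the same structure as compound 3, and the full gain is not assured. A lower number is still expected, estimated as a 4.2-fold lower number from compound 1 to compound 4 (0.62 log units; beyond the scatter). For compound 4 the expected value is 250 nM, within 60 nM to 1000 nM.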

Compound 4, half-maximal effective concentration: 898 nM
Estimate against measurement, compound 4: 3.6-fold (0.56 log units) below, and the stated range covers the measured number.
By their numbers in this assay, from the lowest: compound 3; then compound 2; then compounds 4 and 1 (each within the scatter of the next).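

Placed next to the ring nitrogen and meta to a large group, chloro in place of hydrogen gives a 1.2-fold lower number from compound 1 to compound 4 (0.07 log units; within the scatter) in this assay and so cannot be told apart from the parent. The same exchange at its place in compound 3 gives a 35-fold lower number from compound 1 to compound 3 (1.54 log units; beyond the scatter), so among these compounds the outcome of adding chloro depends on where it sits on the ring. Nothing available explains this contrast.
On these data alone, whether a different group at this position, such as an amine or a methoxy group, would lower the number remains open.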